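A few compounds are considered here, and "the series" means these few. Any claim that something is new, unique, unknown or untested is made for them only; others in the source may bear on it.

Measured compounds: compound 1 `c1cc(CNC2CCN(CCCc3c[nH]c4ccc(-n5cnnc5)cc34)CC2)co1` with 78 nM in an assay on CHO cells for displacement of a labelled ligand from 5-hydroxytryptamine receptor 1B (Homo sapiens) (on this read-out lower numbers stand for stronger inhibition and higher numbers for weaker inhibition), and compound 2 `c1ccc(NCC2CCN(CCCc3c[nH]c4ccc(-n5cnnc5)cc34)CC2)nc1` with 3.3 nM in this assay.

For the measured compounds named here, compound 2 holds the lowest of the two numbers; the only measured step, a 24-fold lower number from compound 1 to compound 2 (1.37 log units; beyond the scatter), separates it from compound 1. Compound 3 `c1ccc2c(c1)CCC2NCC1CCN(CCCc2c[nH]c3ccc(-n4cnnc4)cc23)CC1` differs from compound 2 by 2,3-dihydro-1H-inden-1-yl in place of pyridin-2-yl on an amine nitrogen. That one step shows the group on this amine can shift the number strongly, but it changed a different group, so it fixes no direction for compound 3. Compound 1, which like the incoming group carries no acceptor in this part, gave the higher number. Compound 3 is therefore expected to show a moderate rise, a 4.5-fold higher number from compound 2 to compound 3 (0.66 log units; beyond the scatter). Compound 3 is estimated at 15 nM, within 3 nM to 80 nM.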

Compound 3, half-maximal inhibitory concentration: 25 nM
Estimate against measurement, compound 3: 1.7-fold (0.22 log units) below; the measured number falls inside the stated range.
By their numbers in this assay, from the lowest: compound 2; then compound 3; then compound 1.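

In this assay, replacing pyridin-2-yl on the amine nitrogen with a carbon-only bicyclic group costs affinity, a 7.6-fold higher number from compound 2 to compound 3 (0.88 log units; beyond the scatter), so this position responds to a change of the group even with the ((...)amino)methyl link kept. The same group still improves on the furan-bearing side chain, a 3.1-fold lower number from compound 1 to compound 3 (0.49 log units; beyond the scatter), so pyridin-2-yl is not required for a number lower than that of the furan compound. Nothing measured here explains either step.

The step changes the ring nitrogen and the added saturated ring together, and the two remain unseparated. A plain phenyl on this amine nitrogen would bear on that question.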